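This account rests on a few compounds, and the source may have more. Where it says the series, first, only, none or still open, it means among the compounds named here.

Measured compounds:
compound 1 `O=C(c1cc(Cc2n[nH]c(=O)c3ccccc23)ccc1F)N1CCc2nc(Cl)ncc2C1` — "nd" (no result reported)
compound 2 `CCN1CCN(c2ncc3c(n2)CCN(C(=O)c2cc(Cc4n[nH]c(=O)c5ccccc45)ccc2F)C3)CC1` — 137000 nM

Compound 1 stands without a number: in a functional assay on HCC1937 cells (Homo sapiens) for inhibition, read by MTT assay, with a stated time of 48 h (on this read-out higher numbers stand for weaker inhibition and lower numbers for stronger inhibition), compound 1 gives "nd" (no result reported), so its place cannot be read from the values shown. In this assay compound 2 gives 137000 nM. Compound 3 `CCN(CC)c1ncc2c(n1)CCN(C(=O)c1cc(Cc3n[nH]c(=O)c4ccccc34)ccc1F)C2` arises from compound 1 by diethylamino in place of chloro on an aromatic carbon. With no number for compound 1, the size and direction of this step in this assay cannot be stated; the expectation rests on compound 2 alone. Compound 3 is therefore expected near 120000 nM, within a range of 30000 nM to 500000 nM.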

Compound 3, half-maximal inhibitory concentration: 66800 nM
Beside the measured number, compound 3's estimate is 1.8-fold (0.25 log units) above it, within the range that was stated.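

In this assay, the aromatic carbon between two ring nitrogen atoms responds to the choice of amine, with a 2.1-fold lower number from compound 2 to compound 3 (0.31 log units; beyond the scatter) when diethylamino replaces 4-ethylpiperazin-1-yl. From the compounds shown here alone, the step from the chloro compound 1 cannot be read, so what either amine does relative to chloro stays unknown. Nothing available explains the difference between the two amines. The compounds shown leave open whether a smaller dimethylamino group, a morpholine ring or a primary amine at this carbon would lower the number further.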